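Replacing the methylpiperazine with a dichlorophenyl group

The compounds below may be only part of what the source reports. "The series", "measured", "known", "first", "only" and "open" are said of these compounds alone.

Measured compounds:
- compound 1 `O=C1C(Nc2ccc(C3CCCCC3)cc2)=CC(=O)c2ncncc21`: 1200 nM
- compound 2 `CN1CCN(c2ccc(NC3=CC(=O)c4ncncc4C3=O)cc2)CC1`: 530 nM

In a functional assay on MIA PaCa-2 cells (Homo sapiens) for cytotoxicity, read by MTT assay, with a stated time of 72 h (on this read-out lower numbers stand for stronger inhibition and higher numbers for weaker inhibition), compound 1 gives 1200 nM and compound 2 gives 530 nM. Among the measured compounds shown here, compound 2 stands as the lowest of the two numbers, the only other being compound 1, and the step of a 2.3-fold lower number from compound 1 to compound 2 (0.35 log units; beyond the scatter) went beyond the usual scatter.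

Compound 3 `O=C1C(Nc2ccc(-c3cc(Cl)cc(Cl)c3)cc2)=CC(=O)c2ncncc21` has not yet been measured. It differs from compound 2 in one place: 3,5-dichlorophenyl in place of 4-methylpiperazin-1-yl on an aromatic carbon. The group that leaves is the same 4-methylpiperazin-1-yl that entered in the step from compound 1 to compound 2, and the group that enters, like the cyclohexyl of compound 1, is a six-membered ring of carbon only with no hydrogen-bond acceptors. For the measured compounds named here, that single step, a 2.3-fold lower number from compound 1 to compound 2 (0.35 log units; beyond the scatter), is the only guide here, and the new change runs the opposite way in its counted features. A modest step upward is therefore expected, a 1.9-fold higher number from compound 2 to compound 3 (0.28 log units; within the scatter), taking compound 3 back toward the value of compound 1. For compound 3 the expected value in this assay is 1000 nM, within a range of 400 nM to 3000 nM.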

Compound 3, half-maximal inhibitory concentration: 3100 nM
Compound 3: the middle estimate sits 3.1-fold (0.49 log units) below what was measured; measured number above the stated range.
By their numbers in this assay, from the lowest: compound 2; then compound 1; then compound 3.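

With this assay as the read-out, this position, on an aromatic carbon para to a large group, proves more sensitive than the first pair suggested: 3,5-dichlorophenyl in place of 4-methylpiperazin-1-yl gives a 5.8-fold higher number from compound 2 to compound 3 (0.77 log units; beyond the scatter) and so moves the number further than a 2.3-fold lower number from compound 1 to compound 2 (0.35 log units; beyond the scatter) did. The two groups without hydrogen-bond acceptors also part ways, as 3,5-dichlorophenyl in place of cyclohexyl gives a 2.6-fold higher number from compound 1 to compound 3 (0.41 log units; beyond the scatter) and shows that the acceptor count alone does not set the number, even though compound 2, the only one of the three whose group carries acceptors, stays lowest. No measurement at hand accounts for these differences.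

The compounds shown leave open whether the low number of compound 2 needs the whole 4-methylpiperazin-1-yl ring, or whether a morpholine ring or an open-chain dimethylamino group would serve as well. They also leave open whether the two chlorines matter, since a plain phenyl group could fall near compound 1, near compound 3, or somewhere else.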